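Trifluoromethoxy to ethoxy in the cytotoxicity series

The source may hold more compounds than are shown below. What is called first, only, known or untested is meant among the compounds shown, and "the series" means these compounds.

Measured compounds:
compound 1 `COc1cccc2[nH]c(C(=O)N[C@@H](CC(C)C)C(=O)N[C@H](C#N)C[C@@H]3CCCNC3=O)cc12`: > 200000 nM (a limit)
compound 2 `CC(C)C[C@H](NC(=O)c1cc2c(OC(F)(F)F)cccc2[nH]1)C(=O)N[C@H](C#N)C[C@@H]1CCCNC1=O`: 90000 nM
compound 3 `COc1cccc2[nH]c(C(=O)N[C@@H](CC(C)C)C(=O)N[C@H](C#N)C[C@@H]3CCNC3=O)cc12`: > 200000 nM (a limit)

All three were tested in a toxicity assay on A549 cells (Homo sapiens) for cytotoxicity, read by CCK-8 assay; on this read-out higher numbers stand for lower toxicity in this test and lower numbers for higher toxicity in this test. Compound 2 is the only one of the three with a true number, 90000 nM. Compound 1 and compound 3 both stand at the limit of > 200000 nM in this assay, at which 2 of the 3 values shown sit.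

Compound 4 `CCOc1cccc2[nH]c(C(=O)N[C@@H](CC(C)C)C(=O)N[C@H](C#N)C[C@@H]3CCCNC3=O)cc12` differs from compound 2 as follows: ethyl in place of trifluoromethyl on an oxygen on an aromatic ring. This puts ethyl in place of trifluoromethyl on an oxygen on an aromatic ring.

The measured step that bears on this is an at least 2.2-fold lower number from compound 1 to compound 2 (0.34 log units; beyond the scatter). It changes the group on the same oxygen, and its size is open on one side. The other measured step, a step that the two limits leave unreadable from compound 1 to compound 3, changes a different part of the molecule and cannot be read, so it adds nothing here.

Within the data shown here, on the one readable step, the trifluoromethyl group goes with the lower number, so removing it is expected to move the value up, towards the limit. The expected step is a 2.0-fold higher number from compound 2 to compound 4 (0.30 log units; within the scatter), in the direction of lower toxicity in this test. A result reported only as a limit would fit this expectation. For compound 4 the estimated value is 180000 nM, with an expected range of 80000 nM to 350000 nM.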

Compound 4, half-maximal cytotoxic concentration: > 200000 nM
Compound 4: only a limit was reported; the forecaster's own chance of this, stated with the estimate: 50%; middle value at least 1.1-fold (0.04 log units) away from the limit.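

In this assay, ethyl in place of trifluoromethyl on the oxygen gives an at least 2.2-fold higher number from compound 2 to compound 4 (0.34 log units; beyond the scatter), so compound 2 now differs beyond the scatter from a second group on this oxygen and not only from methyl. Compound 4 gives > 200000 nM, which is a limit and not a number. Among the groups on this oxygen, methyl and ethyl both leave the read-out at the limit, while only trifluoromethyl goes with a measured value, so the extra carbon of ethyl does not bring the number into the measurable range, and compound 2 remains the one exception in the series: the limit of > 200000 nM in this assay, at which 3 of the 4 values shown sit.

Steps between two compounds that both stand at the limit cannot be read, so methoxy and ethoxy cannot be ordered against each other. As far as these compounds go, whether the lower number of compound 2 follows from the fluorine atoms or from the size of the group stays open, and difluoromethoxy or a longer chain such as propoxy on the aromatic ring in the same place would separate the two readings.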